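The source may hold more compounds than are shown below. What is called first, only, known or untested is meant among the compounds shown, and "the series" means these compounds.

Three compounds built on one shared core were run in a functional assay on HepG2 cells (Homo sapiens) for inhibition, read by MTT assay, with a stated time of 48 h; a higher number here means a weaker inhibitor, a lower number a stronger inhibitor. Compound 1 `Clc1ccc(CSc2nnc(-c3ccncc3)n2-c2ccccc2)cc1` gives 16900 nM in this assay, and compound 2 `Brc1ccc(CSc2nnc(-c3ccncc3)n2-c2ccccc2)cc1` gives 12900 nM. The change between them, (chloro in place of bromo on an aromatic carbon), produced a 1.3-fold higher number from compound 2 to compound 1 (0.12 log units; within the scatter). Compound 3 `O=C(CSc1nnc(-c2ccncc2)n1-c1ccccc1)N/N=C/c1ccc(Br)cc1` gives 5990 nM, the lowest of the three numbers; how its core differs from that of compound 2 is not broken down here. Compound 4 `O=C(CSc1nnc(-c2ccncc2)n1-c1ccccc1)N/N=C/c1ccc(Cl)cc1` has not yet been measured. It differs from compound 3 by chloro in place of bromo on an aromatic carbon, the same change as that from compound 2 to compound 1, made at the same place. Because a 1.3-fold higher number from compound 2 to compound 1 (0.12 log units; within the scatter) stayed within the scatter, the step expected for compound 4 is a 1.3-fold higher number from compound 3 to compound 4 (0.10 log units; within the scatter). The estimate for compound 4 in this assay is 7500 nM, between 4000 nM and 14000 nM.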

Compound 4, half-maximal inhibitory concentration: 11000 nM
The estimate for compound 4 lay 1.5-fold (0.17 log units) below the measured number; the range from low to high includes it.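

In this assay, chloro in place of bromo gave a 1.8-fold higher number from compound 3 to compound 4 (0.26 log units; within the scatter) on the core that carries the longer chain. The same change on the two cores gave steps that do not differ: the same change on two cores in this assay, a 1.3-fold higher number (0.12 log units; within the scatter) from compound 2 to compound 1 and a 1.8-fold higher number (0.26 log units; within the scatter) from compound 3 to compound 4, 1.4-fold (0.15 log units) apart, within the scatter of two such steps. This shows that the change carried from one core to the other without a detectable difference, but since both steps lie within the scatter and only two cores are shown, it does not show that the change has a real effect on either core or that it would carry to a third.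

The compounds shown leave open how fluoro, methoxy or an amine would compare with bromo and chloro at this place. They also leave open whether any such group would give a step beyond the scatter on either core.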